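Swapping Methoxy for Nitro on the Aryl Ring

The source may hold more compounds than are shown below. What is called first, only, known or untested is meant among the compounds shown, and "the series" means these compounds.

Measured so far, in a functional assay on HT-29 cells (Homo sapiens) for antiproliferative activity, read by MTT assay, with a stated time of 96 h; a lower number here means a stronger inhibitor, a higher number a weaker inhibitor:
compound 1 `CN(C)c1ccc(N2C(=O)NC3(CSC4=C3C(=O)c3ncccc3C4=O)C2=O)cc1` gives 20 nM
compound 2 `COc1ccc(N2C(=O)NC3(CSC4=C3C(=O)c3ncccc3C4=O)C2=O)cc1` gives 2 nM
compound 3 `O=C1NNC(=O)C2(CSC3=C2C(=O)c2ncccc2C3=O)N1` gives 1580 nM; 1600 nM; 1600 nM (3 entries)

Compound 2 stands lowest of the two single numbers in this assay, with compound 1 the nearest neighbour. Among the compounds with values here, the only step measured between two compounds differing in one place is a 10-fold lower number from compound 1 to compound 2 (1.00 log units; beyond the scatter), a change of methoxy in place of dimethylamino on an aromatic carbon. Compound 3, which carries no aryl group at all, sits far higher in this assay at 1580 nM; 1600 nM; 1600 nM (3 entries).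

Compound 4 `O=C1C2=C(C(=O)c3ncccc31)C1(CS2)NC(=O)N(c2ccc([N+](=O)[O-])cc2)C1=O` differs from compound 2 by nitro in place of methoxy on an aromatic carbon. Within the data shown here, no measured step swaps one aryl substituent for a nitro group, so the earlier step is only a loose guide to a change of similar size. Compound 4 is therefore expected to land near 12 nM, within 2 nM to 80 nM, which means an expected step of a 6.0-fold higher number from compound 2 to compound 4 (0.78 log units; beyond the scatter).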

Compound 4, half-maximal inhibitory concentration: 250 nM
The estimate for compound 4 lay 21-fold (1.32 log units) below the measured number; measured number above the stated range.
By their numbers in this assay, from the lowest: compound 2; then compound 1; then compound 4.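

The group on this aromatic carbon matters more than the first pair suggested: nitro in place of methoxy gives a 130-fold higher number from compound 2 to compound 4 (2.10 log units; beyond the scatter), a much larger step than any seen before. Nitro also falls short of dimethylamino, with a 13-fold higher number from compound 1 to compound 4 (1.10 log units; beyond the scatter), so among these three groups it gives the weakest inhibitor. Nothing measured here explains why nitro costs so much.

Still open, as far as these compounds go, is where a plain amine or a carboxylic acid on the same carbon would land. Also open, from the compounds shown here alone, is whether a chlorine there would behave more like methoxy or more like nitro.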